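This account rests on a few compounds, and the source may have more. Where it says the series, first, only, none or still open, it means among the compounds named here.

The measured compounds so far:

- Compound 1, `N#Cc1cccc(Cn2nc(-c3ccc(CO)o3)c3ccccc32)c1`, gives 26000 nM in a functional assay (aorta) with Oryctolagus cuniculus as the target; a higher number here means a weaker inhibitor, a lower number a stronger inhibitor.
- Compound 2, `Fc1ccccc1Cn1nc(-c2ccco2)c2cccnc21`, gives 9300 nM in this assay.
- Compound 3, `NS(=O)(=O)c1ccc(-c2nn(Cc3ccccc3F)c3ncccc23)o1`, gives 8000 nM in this assay.

Compound 2 stands second highest of these three numbers. Its nearest neighbour is compound 3, and the step of a 1.2-fold lower number from compound 2 to compound 3 (0.07 log units; within the scatter) sits within the usual scatter, so the two cannot be ranked against each other. Its furthest neighbour is compound 1, whose higher number lies beyond the scatter.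

Compound 4, `Cc1cc(N)nc(-c2nn(Cc3ccccc3F)c3ncccc23)n1`, is not yet measured. It differs from compound 2 in one place: 4-amino-6-methylpyrimidin-2-yl in place of furan-2-yl on an aromatic carbon. Among the measured compounds shown here, the only single-change step measured, from compound 2 to compound 3, alters a group on the furan-2-yl ring and does not exchange that ring, so it gives no direct guide here. For the measured compounds named here, no measured pair shows what replacing the whole ring does. With nothing to point either way, the number for compound 4 is expected to stay close to that of compound 2, with wide uncertainty. The expected step is a 1.0-fold lower number from compound 2 to compound 4 (0.01 log units; within the scatter). Compound 4 is therefore estimated at 9000 nM, in a range from 2500 nM to 35000 nM.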

Compound 4, half-maximal inhibitory concentration: 536000 nM
Estimate against measurement, compound 4: 60-fold (1.77 log units) below; the whole stated range lies below it.
By their numbers in this assay, from the lowest: compounds 3 and 2 (each within the scatter of the next); then compound 1; then compound 4.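

This position on the shared core is clearly sensitive to what it carries: in this assay, 4-amino-6-methylpyrimidin-2-yl in place of furan-2-yl gives a 58-fold higher number from compound 2 to compound 4 (1.76 log units; beyond the scatter), making compound 4 a much weaker inhibitor. The earlier step, a 1.2-fold lower number from compound 2 to compound 3 (0.07 log units; within the scatter), only added sulfamoyl to the furan-2-yl ring, whereas this exchange replaces the ring itself and moves the number far more. No measurement here explains why the exchange weakens inhibition.

The exchange alters several things at once, including ring size, hetero atoms and the added amino and methyl groups, and this single pair cannot separate them. Going by these compounds, it remains open whether a plain pyrimidin-2-yl, without the amine or methyl, or a thiophen-2-yl would keep a number close to that of compound 2.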